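Extending a Weak Inhibitor with a Pyridinyl Arm

The compounds below may be only part of what the source reports. "The series", "measured", "known", "first", "only" and "open" are said of these compounds alone.

Measured compounds:
compound 1 `Cc1cc(-c2c(C)nn(C)c2C)cnc1-c1nnc(N(C)Cc2ccc3nccn3c2)o1` — 6310 nM
compound 2 `Cc1cc(-c2c(C)nc(C)n2C)ccc1-c1nnc(N(C)Cc2ccc3nccn3c2)o1` — 5010 nM

Of the compounds shown here, two have been measured in an assay on COS-7 cells for inhibition of tyrosine-protein kinase receptor UFO (Homo sapiens), read by ELISA, with a stated time of 1 h; on this read-out lower numbers stand for stronger inhibition and higher numbers for weaker inhibition. Compound 1 gives 6310 nM, and compound 2 gives 5010 nM. Compound 1 has the highest of the two numbers, but its gap to compound 2 lies within the scatter of the assay, so the two cannot be told apart on this data. Both numbers sit in the weak range.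

Compound 3 `Cc1cc(-c2c(C)nn(C)c2C)cnc1-c1nnc(N(C)Cc2ccc3ncc(-c4ccc(CN(C)C)cn4)n3c2)o1` grows out of compound 1 by a single change: 5-((dimethylamino)methyl)pyridin-2-yl in place of hydrogen on an aromatic carbon. A sizeable group is thus attached to the fused bicyclic part of the molecule, on an aromatic carbon of a five-membered aromatic ring with two nitrogens, next to the ring nitrogen.

For the measured compounds named here, no pair of measured compounds shows what such an addition does in this assay, so any expectation rests on the change itself. An addition of this size at this position is expected to lower the number, meaning stronger inhibition, by a moderate step, with wide uncertainty in both directions. For compound 3 the expected step is a 4.2-fold lower number from compound 1 to compound 3 (0.62 log units; beyond the scatter). Compound 3 is therefore estimated at 1500 nM, within a range from 200 nM to 8000 nM.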

Compound 3, half-maximal inhibitory concentration in the tyrosine-protein kinase receptor UFO assay: 126 nM
Compound 3: middle estimate off by 12-fold (1.08 log units), on the high side; the measured number lies below the stated range.
By their numbers in the tyrosine-protein kinase receptor UFO assay, from the lowest: compound 3; then compounds 2 and 1 (each within the scatter of the next).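

The aromatic carbon of the fused bicyclic part, bare in compound 1 and compound 2, accepts a large group and is a position that strongly affects inhibition: in the tyrosine-protein kinase receptor UFO assay the 5-((dimethylamino)methyl)pyridin-2-yl arm gives a 50-fold lower number from compound 1 to compound 3 (1.70 log units; beyond the scatter) and lifts a weak inhibitor well clear of the earlier pair, with compound 3 at 126 nM. In a physicochemical assay for lipophilicity, at pH 7.4 (a lower number here means a more polar compound, a higher number a more lipophilic compound), compound 1 gives 2.8 and compound 3 gives 3, and the same addition gives a number 0.20 log units higher from compound 1 to compound 3 (within the scatter) even though it brings 10 heavy atoms, so on this read-out compound 1 and compound 3 cannot be told apart, and the stronger inhibition comes with no measurable rise in the distribution coefficient. Nothing in the available data accounts for the size of the step in inhibition.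

The compounds shown leave open whether the step belongs to the pyridine ring or to the dimethylamino end of the arm: a plain pyridin-2-yl, a phenyl ring, or a morpholine in place of the dimethylamino group would separate the two. On these data alone, whether the same arm gives a similar step on the core of compound 2 also remains open.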